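Antiproliferative values on phenyl-substituted analogues of compound 1

The source may hold more compounds than are shown below. What is called first, only, known or untested is meant among the compounds shown, and "the series" means these compounds.

- Compound 1 `CCCCc1cc2c(=O)c(-c3ccccc3)c(C)[nH]c2cc1OCCOc1ccccc1` in an ADME assay on J774 cells (Mus musculus) for antiproliferative activity, with a stated time of 72 h (a higher number here means that more compound is needed for the effect, a lower number that less compound is needed), gives 23000 nM
- Compound 2 `CCCCc1cc2c(=O)c(-c3cccc(Oc4ccc(F)cc4)c3)c(C)[nH]c2cc1OCCOc1ccccc1` gives 19000 nM
- Compound 3 `CCCCc1cc2c(=O)c(-c3ccc(COc4ccc(OC(F)(F)F)cc4)cc3)c(C)[nH]c2cc1OCCOc1ccccc1` gives 16000 nM

Compound 1 lies within the usual scatter of both compound 2 and compound 3, so no order can be read among these three values. The next comparison is with compound 4 `CCCCc1cc2c(=O)c(-c3ccc(C(F)(F)F)cc3C)c(C)[nH]c2cc1OCCOc1ccccc1`, which differs from compound 1 as follows: 2-methyl-4-(trifluoromethyl)phenyl in place of phenyl on an aromatic carbon with 2-methyl-4-(trifluoromethyl)phenyl in place of phenyl on an aromatic carbon. Within the data shown here, the one measured step on that phenyl is a 1.2-fold lower number from compound 1 to compound 2 (0.08 log units; within the scatter) and it stays within the scatter. Compound 3, also substituted on that phenyl, gives 16000 nM and remains within the scatter of compound 1. Among the measured compounds shown here, no measured compound carries the entering group itself. In this assay no step beyond the scatter is therefore expected, and no direction can be called with confidence. An estimated 1.2-fold lower number from compound 1 to compound 4 (0.08 log units; within the scatter) is the working expectation. The estimated value for compound 4 is 19000 nM (expected range 10000 nM to 33000 nM).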

Compound 4, half-maximal effective concentration: 20000 nM
Compound 4: the middle estimate sits 1.1-fold (0.02 log units) below what was measured, within the range that was stated.
By their numbers in this assay, from the lowest: compounds 3, 2, 4 and 1 (each within the scatter of the next).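

In this assay, 2-methyl-4-(trifluoromethyl)phenyl in place of phenyl gives a 1.2-fold lower number from compound 1 to compound 4 (0.06 log units; within the scatter), so a third substituted phenyl at this position stays within the scatter of compound 1. Compound 2 and compound 3 both carry a second aromatic ring on that phenyl through an ether link, whereas compound 4 has only methyl and trifluoromethyl on it, and this very different kind of substitution also leaves the number within the scatter. Nothing available explains why the number stays there.

On these data alone, whether any group on this phenyl can move the number beyond the scatter remains open, as a primary amine or a carboxylic acid there would be a different test from the neutral groups seen so far. The compounds shown also leave open whether a change elsewhere on the shared core would do so.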